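Trifluoromethyl in place of hydrogen on compound 2

A few compounds are considered here, and "the series" means these few. Any claim that something is new, unique, unknown or untested is made for them only; others in the source may bear on it.

- compound 1 `COc1ccc(/C2=C\C(=O)/C(C)=C\C3=C[C@H](C)C[C@@]34OC(=C(C)C4=O)CC2(C)C)cc1`: 26000 nM
- compound 2 `CC1=C2CC(C)(C)/C(c3ccccc3)=C/C(=O)/C(C)=C\C3=C[C@H](C)C[C@]3(O2)C1=O`: 26000 nM

In an ADME assay on BJ cells (Homo sapiens) for cytotoxicity, read by CellTiter-Glo, with a stated time of 72 h (on this read-out higher numbers stand for an effect only at larger amounts of compound and lower numbers for an effect already at smaller amounts), compound 2 gives 26000 nM, level with compound 1 at the digits shown. Compound 3 `CC1=C2CC(C)(C)/C(c3ccc(C(F)(F)F)cc3)=C/C(=O)/C(C)=C\C3=C[C@H](C)C[C@]3(O2)C1=O` has trifluoromethyl in place of hydrogen on an aromatic carbon, para to a large group: trifluoromethyl in place of hydrogen on an aromatic carbon. Going by the values given here, only one measured step bears on this, a swap of hydrogen for methoxy on an aromatic carbon, and it showed no change at the digits printed from compound 1 to compound 2 (within the scatter). That is thin evidence for a different group, but it gives no reason to expect a step beyond the scatter in this assay. The expected change is a 1.0-fold lower number from compound 2 to compound 3 (0.02 log units; within the scatter). Compound 3 is estimated at 25000 nM, with an expected range from 11000 nM to 50000 nM.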

Compound 3, half-maximal effective concentration: 26000 nM
For compound 3 the middle estimate is 1.0-fold (0.02 log units) below the measured one; the range from low to high includes it.
By their numbers in this assay, from the lowest: compounds 1, 2 and 3 (each within the scatter of the next).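

In this assay, the aromatic carbon para to a large group has now carried three groups: replacing hydrogen with trifluoromethyl gives no change at the digits printed from compound 2 to compound 3 (within the scatter), and replacing methoxy with trifluoromethyl gives no change at the digits printed from compound 1 to compound 3 (within the scatter), so the lack of a step is no longer confined to one pair. Hydrogen, methoxy and trifluoromethyl all sit level here, whereas the earlier compounds compared only the first two. No measurement shown explains this flat result. Going by these compounds, whether an amine or a carboxylic acid at this carbon would give a different number remains open, as does the effect of changes elsewhere on the shared core.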